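This account rests on a few compounds, and the source may have more. Where it says the series, first, only, none or still open, it means among the compounds named here.

Measured compounds:
compound 1 `COc1cc(NC(C)CCCNC(=O)NNC(=O)Nc2cc(C(F)(F)F)cc(C(F)(F)F)c2)c2ncccc2c1`: 17000 nM
compound 2 `COc1cc(NC(C)CCCNC(=O)NNC(=O)Nc2ccc(Br)cc2)c2ncccc2c1`: 101000 nM

The account concerns two compounds that share a core and differ only in the group hanging from the far end of the chain. In a functional assay on HeLa cells (Homo sapiens) for inhibition, read by MTT assay, with a stated time of 72 h (a lower number here means a stronger inhibitor, a higher number a weaker inhibitor), compound 1 gives 17000 nM. In this assay compound 2 gives 101000 nM, the higher of the two numbers; its nearest neighbour is compound 1, whose number lies lower by a gap beyond the usual scatter, so compound 2 counts as the weaker of the pair on these numbers.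

The step now followed leads from compound 2 to compound 3 `COc1cc(NC(C)CCCNC(=O)Nc2cccc(F)c2)c2ncccc2c1`, which has not yet been measured in this assay. The change is 3-fluorophenyl in place of ((4-bromophenyl)carbamoyl)amino on an amide-type nitrogen. Within the data shown here, no step between measured compounds matches this change, so nothing measured tells how much of the potency of compound 2 rests on that group. With only compound 1 and compound 2 to go by, the expectation for the step of a 1.7-fold lower number from compound 2 to compound 3 (0.23 log units; within the scatter) is a change of modest size, most likely a slight move toward a lower number, though a step within the scatter would not surprise. Compound 3 is expected to give about 60000 nM in this assay, in a range from 15000 nM to 250000 nM.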

Compound 3, half-maximal inhibitory concentration: 18000 nM
For compound 3 the middle estimate is 3.3-fold (0.52 log units) above the measured one; the range from low to high includes it.
By their numbers in this assay, from the lowest: compounds 1 and 3 (each within the scatter of the next); then compound 2.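

In this assay, a 5.6-fold lower number from compound 2 to compound 3 (0.75 log units; beyond the scatter) shows that the ((4-bromophenyl)carbamoyl)amino group on the amide-type nitrogen is not required for the activity of compound 2: with 3-fluorophenyl in its place, which has fewer heavy atoms, the number falls rather than rises. Compound 1 gives 17000 nM and compound 3 gives 18000 nM, values within the usual scatter of each other, so a much shorter end group on this nitrogen matches the best number seen so far for the longer type. Nothing measured on the compounds explains this step.

Going by these compounds, what remains open is how the step divides between the loss of the carbamoyl-and-nitrogen link and the change of the ring and its halogen, as both change together here. A 4-bromophenyl group placed on the amide-type nitrogen would separate these two parts, and a plain phenyl group or a 3-fluorophenyl group carried on the longer link would show how much the fluorine itself contributes.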